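This account rests on a few compounds, and the source may have more. Where it says the series, first, only, none or still open, it means among the compounds named here.

In an ADME assay on microsomes from liver (Homo sapiens) for metabolic stability, read by LC-MS, with a stated time of 30 min, tested at 1 uM (on this read-out lower numbers stand for a less stable compound and higher numbers for a more stable compound), compound 1 `O=C(NCc1ccc(S(=O)(=O)c2ccccc2)cc1)c1cc2ccncc2s1` gives 48%, the lower of the two numbers recorded so far, while compound 2 `O=C(NCc1ccc(S(=O)(=O)N2CCCCC2)cc1)c1ccn2cncc2c1` gives 54% in this assay, a gap that sits within the usual scatter. Compound 3 `O=C(NCc1ccc(S(=O)(=O)c2ccccc2)cc1)c1cc2cnccc2[nH]1` awaits measurement; relative to compound 1 it carries a group of 9 heavy atoms (7 carbon, 2 nitrogen; one five-membered aromatic ring with 1 hetero atom, one six-membered aromatic ring with 1 hetero atom) in place of a group of 9 heavy atoms (7 carbon, 1 nitrogen, 1 sulfur; one five-membered aromatic ring with 1 hetero atom, one six-membered aromatic ring with 1 hetero atom), on a carbonyl carbon. Among the compounds with values here, no pair of measured compounds differs in a single place, so no step of known size guides the expectation. The author expects only a small step, in either direction or none beyond the scatter, as a number 4 percentage points higher from compound 1 to compound 3 (within the scatter). For compound 3 she estimates 52%, with a range from 28% to 76%.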

Compound 3, percent of the compound remaining: 75%
Compound 3: middle estimate off by 23 percentage points, on the low side, within the range that was stated.
By their numbers in this assay, from the lowest: compounds 1 and 2 (each within the scatter of the next); then compound 3.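

In this assay, putting the group of 9 heavy atoms with 7 carbon and 2 nitrogen in place of the one with 7 carbon, 1 nitrogen and 1 sulfur, on a carbonyl carbon, gives a number 27 percentage points higher from compound 1 to compound 3 (beyond the scatter). This position therefore responds to a change that keeps the heavy-atom count and both ring sizes, while the hydrogen-bond donors go from 0 to 1. Nothing measured here accounts for the step.

On these data alone, what a methyl group on the donor nitrogen would do stays open. So does whether the step would carry over to the sulfonyl piperidine side of compound 2.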